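The source may report more compounds than this note shows. Statements on the series, on what has been measured and on what is new or still open speak of the compounds shown alone.

Compound 3, `CCN(CC)S(=O)(=O)c1ccc(S(=O)(=O)N2CCC[C@@H](C(=O)N[C@@H]3CCOC3)C2)cc1`, is the starting point of this comparison. In a functional assay on MIA PaCa-2 cells (Homo sapiens) for inhibition, read by MTT assay, with a stated time of 3 days (on this read-out lower numbers stand for stronger inhibition and higher numbers for weaker inhibition), compound 3 returns only a limit, > 10000 nM, so no number is known for it. The two compounds that share its core stand the same way. Compound 1, `CCN(CC)S(=O)(=O)c1ccc(S(=O)(=O)N2CCC[C@@H](C(=O)N3CCC(C(F)(F)F)CC3)C2)cc1`, gives in this assay the limit > 10000 nM. Compound 2, `CCN(CC)S(=O)(=O)c1ccc(S(=O)(=O)N2CCC[C@@H](C(=O)N[C@H]3CC[C@@H](OC)CC3)C2)cc1`, gives in this assay the limit > 10000 nM. All three values therefore sit at the limit of > 10000 nM in this assay, at which 3 of the 3 values shown sit, and the steps between them, a step that the two limits leave unreadable from compound 1 to compound 2, a step that the two limits leave unreadable from compound 1 to compound 3 and a step that the two limits leave unreadable from compound 2 to compound 3, cannot be read in size or direction.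

Compound 4, `CCN(CC)S(=O)(=O)c1ccc(S(=O)(=O)N2CCC[C@@H](C(=O)N3CCC(C(F)F)CC3)C2)cc1`, has not yet been measured. It differs from compound 3 in one place: 4-(difluoromethyl)piperidin-1-yl in place of (oxolan-3-yl)amino on a carbonyl carbon. Among the compounds with values here, of the measured steps, the one from compound 1 to compound 3 touches the same carbonyl carbon and exchanges a related piperidinyl group, but its size is unreadable, as are the other two. Within the data shown here, nothing among the measured compounds shows a step beyond the scatter, and every measured value is a limit.

The expectation for compound 4 is therefore set by the limit at which the series sits: compound 4 is expected to give about 15000 nM, within 5000 nM to 50000 nM, which would mean an estimated step that the limit leaves unreadable from compound 3 to compound 4.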

Compound 4, half-maximal inhibitory concentration: > 10000 nM
Compound 4 gave a limit, no number (the forecaster's own chance of this, stated with the estimate: 85%); the middle value does not contradict the limit.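

In this assay compound 4 gives only a limit, > 10000 nM, so its steps from compound 1, compound 2 and compound 3 cannot be read in size or direction. The series stands unchanged: the limit of > 10000 nM in this assay, at which 4 of the 4 values shown sit.

From the compounds shown here alone, whether any group on this carbonyl carbon would give a measurable value in this assay, and how these four compounds truly compare, stays open.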